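Methoxy removal across two cores in a cytotoxicity series

The source may hold more compounds than are shown below. What is called first, only, known or untested is meant among the compounds shown, and "the series" means these compounds.

Measured so far in a functional assay on 786-0 cells (Homo sapiens) for cytotoxicity, read by sulforhodamine B assay, with a stated time of 48 h, tested at 100 uM; on this read-out lower numbers stand for a stronger effect and higher numbers for a weaker effect at the one concentration tested:
compound 1, `COc1cc(-c2cc(/C=C/C(=O)c3ccc(N)cc3)[nH]n2)cc(OC)c1OC`, gives -90%
compound 2, `COc1ccc(-c2cc(/C=C/C(=O)c3ccc(N)cc3)[nH]n2)cc1OC`, gives -97%
compound 3, `COc1cc(C(=O)/C=C/c2cc(-c3cc(OC)c(OC)c(OC)c3)n[nH]2)cc(OC)c1OC`, gives -98%

Compound 1 and compound 2 share a core and differ in one place: hydrogen in place of methoxy on an aromatic carbon. The step of a number 7 percentage points lower from compound 1 to compound 2 (within the scatter). The core of compound 3 differs from the core of compound 1; the difference between the two cores is not broken down here. In this assay compound 3 and compound 2 lie within the scatter of each other, and the same holds for compound 3 and compound 1, so no order among the three can be read from these numbers.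

Compound 4, `COc1ccc(-c2cc(/C=C/C(=O)c3cc(OC)c(OC)c(OC)c3)[nH]n2)cc1OC`, has not yet been measured. It arises from compound 3 by hydrogen in place of methoxy on an aromatic carbon, the same change as that between compound 1 and compound 2, at a place described in the same words. The expectation for compound 4 rests on compound 1 and compound 2, where the step of a number 7 percentage points lower from compound 1 to compound 2 (within the scatter) stayed within the scatter, and on compound 3, which already gives -98% in this assay and so leaves little room for a further move downward. The step expected in this assay is a number 2 percentage points higher from compound 3 to compound 4 (within the scatter). Compound 4 is estimated at -96% in this assay, with the likely range between -100% and -85%.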

Compound 4, a percentage reported as activity, at one concentration (the size of the read-out at that concentration, not a potency): -90%
Beside the measured number, compound 4's estimate is 6 percentage points below it; the range from low to high includes it.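

On the core of compound 3, hydrogen in place of methoxy on an aromatic carbon in this assay gives a number 8 percentage points higher from compound 3 to compound 4 (within the scatter), and this step does not match the one seen for the same change on the core of compound 1: the same change on two cores in this assay, a number 7 percentage points lower (within the scatter) from compound 1 to compound 2 and a number 8 percentage points higher (within the scatter) from compound 3 to compound 4, 15 percentage points apart, beyond the scatter of two such steps. In these two pairs, the change therefore does not carry from one core to the other as a fixed step, so a step read on one core is a poor guide to the other. Taken alone, each step lies within the scatter, and nothing here shows that the change has an effect of its own on either core, what sets the two steps apart, or how the change would behave on any further core.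

Still open, as far as these compounds go, is whether a hydroxy group or a chlorine atom at this place on an aromatic carbon would give steps that agree between the two cores any better than hydrogen does. From the compounds shown here alone, the read-out for all four compounds comes from one concentration and gives the size of the effect at that concentration, so how the two steps would compare at other concentrations also remains open.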